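The source may report more compounds than this note shows. Statements on the series, on what has been measured and on what is new or still open speak of the compounds shown alone.

Measured compounds:
- compound 1, `CN(C)CCn1ccc2c(NS(=O)(=O)c3ccc4ccccc4c3)cccc21`: 14.9 nM
- compound 2, `CN(C)CCn1ccc2cc(NS(=O)(=O)c3cccc4ccccc34)ccc21`: 94.2 nM
- compound 3, `CN(C)CCn1ccc2cc(NS(=O)(=O)Cc3ccccc3)ccc21`: > 1000 nM

In an assay on HEK293 cells for binding affinity to 5-hydroxytryptamine receptor 6 (Homo sapiens) (on this read-out higher numbers stand for weaker inhibition and lower numbers for stronger inhibition), compound 1 gives 14.9 nM and compound 2 gives 94.2 nM. Of the two numbers, compound 2 stands highest; its nearest neighbour is compound 1, whose number is lower by a margin beyond the usual scatter. Compound 3 reaches only the limit of this assay, (the limit of > 1000 nM in this assay, at which 1 of the 3 values shown sits), so no number can be stated for it.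

Compound 4, `Cc1cc2cc(NS(=O)(=O)c3cccc4ccccc34)ccc2n1CCN(C)C`, has not yet been measured in this assay. It differs from compound 2 in one place: methyl in place of hydrogen on an aromatic carbon, a methyl in place of hydrogen on an aromatic carbon, next to the ring nitrogen and next to the ring atom that bears the 2-(dimethylamino)ethyl group. For the measured compounds named here, no measured pair in this set shows what such a methyl does, so the direction of the step is open. With a single added carbon and the sulfonamide and the dimethylaminoethyl chain left as they are, a step of a size within the scatter is expected. Compound 4 is therefore estimated at 80 nM, between 25 nM and 300 nM, which means an expected step of a 1.2-fold lower number from compound 2 to compound 4 (0.07 log units; within the scatter).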

Compound 4, inhibition constant: 124 nM
Compound 4: the middle estimate sits 1.6-fold (0.19 log units) below what was measured; measured number inside the range.
By their numbers in this assay, from the lowest: compound 1; then compounds 2 and 4 (each within the scatter of the next). At a limit, above all of these: compound 3.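

In this assay, methyl in place of hydrogen on an aromatic carbon of the five-membered aromatic ring gives a 1.3-fold higher number from compound 2 to compound 4 (0.12 log units; within the scatter). For the compounds shown here, this is the first pair in the set that differs in one place, and it shows that this carbon, next to the ring nitrogen and next to the ring atom that bears the 2-(dimethylamino)ethyl group, can carry a methyl without a change that stands out from the scatter, so the two numbers cannot be told apart. Nothing in the available evidence bears on this result, and the data give no reason for it.

What the compounds shown leave open is whether this carbon accepts more than a single carbon, for example an ethyl, an isopropyl or a phenyl group, or a different kind of group such as a chlorine, a methoxy or a carboxylic acid. From the compounds shown here alone, it is also open whether the same methyl would give a similar result on the core of compound 1, which has the lowest number so far at 14.9 nM.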